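Notes on acylation of the amino group in compound 3

The source may report more compounds than this note shows. Statements on the series, on what has been measured and on what is new or still open speak of the compounds shown alone.

Measured so far in an assay on CHO cells for displacement of a labelled ligand from adenosine receptor A1 (Homo sapiens), read by scintillation counting, with a stated time of 120 min, tested at 1 uM; a higher number here means more inhibition at the concentration tested (going by the name of the read-out), a lower number less inhibition:
- compound 1 `COc1ccc(-c2nc3cn(C)nc3c(=O)[nH]2)cc1`: 2%
- compound 2 `Nc1nc(-c2ccc(Cl)cc2)nc2cn(-c3ccccc3)nc12`: 13%
- compound 3 `COc1ccc(-c2nc(N)c3nn(-c4ccccc4)cc3n2)cc1`: 33%

Compound 3 stands highest of the three numbers in this assay. Its nearest neighbour is compound 2, which lies a step beyond the scatter below it; compound 1, with a different core, lies furthest below.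

Going by the values given here, the one step that joins two measured compounds runs a number 20 percentage points higher from compound 2 to compound 3 (beyond the scatter). It concerns the substituent on the pendant aromatic ring and says nothing about the amino group.

Compound 4 `COc1ccc(-c2nc(NC(=O)c3ccncc3)c3nn(-c4ccccc4)cc3n2)cc1` differs from compound 3 by (pyridin-4-yl)carbonyl in place of hydrogen on a nitrogen on an aromatic ring, that is, amino becomes ((pyridin-4-yl)carbonyl)amino. Among the compounds with values here, no measured pair in this set carries a change at that nitrogen, so no step here bears directly on it; the expectation rests on compound 3 alone and is uncertain in both directions.

The step of a number 5 percentage points lower from compound 3 to compound 4 (within the scatter) is therefore expected to stay roughly within the scatter, with a wide range. Compound 4 is estimated at 28%, between 5% and 55%.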

Compound 4, a percentage reported as inhibition, at one concentration (the size of the read-out at that concentration, not a potency): 3%
Estimate against measurement, compound 4: 25 percentage points above; measured number below the stated range.
By their numbers in this assay, from the lowest: compounds 1, 4 and 2 (each within the scatter of the next, the first and the last beyond it); then compound 3.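

In this assay, the change from amino to ((pyridin-4-yl)carbonyl)amino gives a number 30 percentage points lower from compound 3 to compound 4 (beyond the scatter) and is the only step shown at this nitrogen. Unlike the earlier step on the pendant aromatic ring, it shows that the read-out at the concentration tested also responds to a change at this position, and that this large substituent on the nitrogen does not keep the level seen with the free amino group. No supporting data shown here account for the loss.

With a single substituent at this nitrogen, the carbonyl and the pyridin-4-yl ring cannot be separated as the source of the loss. A small acetyl group, a benzoyl group or a simple methyl on the same nitrogen would help to separate them, and the same change on the chloro-substituted compound 2 would test whether the loss carries over.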